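Stereocentre inversion at the saturated ring carbon

The compounds below may be only part of what the source reports. "The series", "measured", "known", "first", "only" and "open" are said of these compounds alone.

Measured so far:
Compound 1 `COC(=O)[C@H](CCSC)NC(=O)c1ccc(OC[C@H]2COc3ccccc3O2)cc1-c1ccccc1OC` gives 230000 nM in a functional assay (HSMC cells, Homo sapiens) for antiproliferative activity, with a stated time of 72 h; on this read-out higher numbers stand for weaker inhibition and lower numbers for stronger inhibition.
Compound 2 `COC(=O)[C@H](CCSC)NC(=O)c1ccc(C(=O)NC[C@H]2COc3ccccc3O2)cc1-c1ccccc1C` gives 87000 nM in this assay.

Compound 2 holds the lower of the two numbers, and its gap to compound 1 lies beyond the usual scatter. Compound 3 `COC(=O)[C@H](CCSC)NC(=O)c1ccc(C(=O)NC[C@@H]2COc3ccccc3O2)cc1-c1ccccc1C` keeps every atom and bond of compound 2: the two compounds have the same atoms and bonds and differ only in configuration as drawn: 1 of 2 stereo elements differ; a stereocentre at a saturated ring carbon is drawn S in compound 2 and R in compound 3. Among the compounds with values here, no measured pair shows an inversion of this kind, so the step has no anchor and may run in either direction or stay within the scatter. Compound 3 is expected at 120000 nM, in the range 40000 nM to 400000 nM. The expected step in this assay is a 1.4-fold higher number from compound 2 to compound 3 (0.14 log units; within the scatter).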

Compound 3, half-maximal inhibitory concentration: 533000 nM
Beside the measured number, compound 3's estimate is 4.4-fold (0.65 log units) below it; measured number above the stated range.
By their numbers in this assay, from the lowest: compound 2; then compound 1; then compound 3.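

The configuration at the saturated ring carbon matters in this assay: inverting it from S to R gives a 6.1-fold higher number from compound 2 to compound 3 (0.79 log units; beyond the scatter). Within the data shown here, this is the first inversion pair, and the S form as drawn holds the lower number. The shift can be assigned to this one stereocentre alone, because of: the fact that compounds 2 and 3 differ only in the configuration as drawn

A single pair cannot show whether the S preference carries over to other compounds on the shared core. Also open, from the compounds shown here alone, is whether it survives a carboxylic acid in place of the methyl ester.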